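Adding a Second Ethyl Group to an Amide Nitrogen

This account rests on a few compounds, and the source may have more. Where it says the series, first, only, none or still open, it means among the compounds named here.

Three compounds sharing one core have been measured:
compound 1 `COc1cc2c(cc1OC)C(CC(=O)O)CC2` gives 24% in a functional assay on the whole organism (strain Wistar) for inhibition, with Rattus norvegicus as the target, read by paw edema, with stated times of 60 min and 2 h, at a dose of 100 mg/kg by the oral route; a higher number here means more inhibition at the dose given (going by the name of the read-out), a lower number less inhibition;
compound 2 `COc1cc2c(cc1OC)C(CC(=O)N(C)C)CC2` gives 36%;
compound 3 `CCNC(=O)CC1CCc2cc(OC)c(OC)cc21` gives 26%.

Compound 3 sits between the other two, yet its gaps to both fall within the usual scatter: a number 2 percentage points higher from compound 1 to compound 3 (within the scatter) and a number 10 percentage points lower from compound 2 to compound 3 (within the scatter). Within the data shown here, the only step beyond scatter is a number 12 percentage points higher from compound 1 to compound 2 (beyond the scatter), a modest gain.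

Compound 4 `CCN(CC)C(=O)CC1CCc2cc(OC)c(OC)cc21` carries the change (ethyl in place of hydrogen on an amide-type nitrogen). This makes the nitrogen fully substituted, as in compound 2. Going by the step from compound 2 to compound 3, which stayed within scatter, no step beyond scatter is expected; a small rise toward compound 2 is the most an estimate can claim, a number 7 percentage points higher from compound 3 to compound 4 (within the scatter). Compound 4 is therefore expected to give about 33%, between 18% and 48%.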

Compound 4, a percentage reported as inhibition, in the whole organism at one dose (the size of the read-out at that dose, not a potency): 40%
Compound 4: the middle estimate sits 7 percentage points below what was measured, and the stated range covers the measured number.
By their numbers in this assay, from the lowest: compounds 1, 3, 2 and 4 (each within the scatter of the next, the first and the last beyond it).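

In this assay ethyl in place of the amide hydrogen gives a number 14 percentage points higher from compound 3 to compound 4 (beyond the scatter) and so shows that this nitrogen responds to a second ethyl group, while a number 4 percentage points higher from compound 2 to compound 4 (within the scatter) leaves diethylamino and dimethylamino not distinguishable from each other. Diethylamino in place of hydroxy gives a number 16 percentage points higher from compound 1 to compound 4 (beyond the scatter) and joins dimethylamino as a group that clears the scatter against the acid, which ethylamino does not do. No measurement at hand explains these steps.

Still open, from the compounds shown here alone, is how the simple unsubstituted amide, a longer chain such as dipropylamino, or a nitrogen held in a ring such as piperidine would compare on this core.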